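This account rests on a few compounds, and the source may have more. Where it says the series, first, only, none or still open, it means among the compounds named here.

Three compounds share one core and differ only in the aromatic group carried on a saturated chain carbon bound to an amide-type nitrogen in a ring. Compound 1 `Cc1noc(C)c1-c1ccc2c(c1)C(c1ccccc1)N(Cc1nnc(-c3ccccc3)o1)C(=O)N2C` carries a 5-phenyl-1,3,4-oxadiazol-2-yl group; in a functional assay on MCF7 cells (Homo sapiens) for inhibition, read by MTT assay, with a stated time of 48 h, tested at 2 uM (on this read-out lower numbers stand for less inhibition and higher numbers for more inhibition at the one concentration tested (going by the name of the read-out)), compound 1 gives 34.1%. Compound 2 `Cc1noc(C)c1-c1ccc2c(c1)C(c1ccccc1)N(Cc1ncc(-c3ccccc3)o1)C(=O)N2C` carries a 5-phenyl-1,3-oxazol-2-yl group; in this assay compound 2 gives 34%. Compound 3 `Cc1nc(-c2ccccc2)sc1CN1C(=O)N(C)c2ccc(-c3c(C)noc3C)cc2C1c1ccccc1` carries a 4-methyl-2-phenyl-1,3-thiazol-5-yl group; in this assay compound 3 gives 35.1%. Compound 2 thus sits within the usual scatter of both companions: the steps of a number 0.1 percentage points lower from compound 1 to compound 2 (within the scatter) and a number 1.1 percentage points higher from compound 2 to compound 3 (within the scatter) are within the scatter, as is a number 1 percentage points higher from compound 1 to compound 3 (within the scatter).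

Compound 4 `Cc1noc(C)c1-c1ccc2c(c1)C(c1ccccc1)N(Cc1nc(-c3ccc(F)cc3)cs1)C(=O)N2C` has not yet been measured. It differs from compound 2 in one place: 4-(4-fluorophenyl)-1,3-thiazol-2-yl in place of 5-phenyl-1,3-oxazol-2-yl on a saturated chain carbon bound to an amide-type nitrogen in a ring. Every measured step at this position exchanged one aromatic group for another and moved the read-out by no more than the scatter, so the same is expected here, with no step beyond the scatter in either direction. The expected step is a number 1 percentage points higher from compound 2 to compound 4 (within the scatter). For compound 4 the expected value in this assay is 35%, between 25% and 45%.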

Compound 4, a percentage reported as inhibition, at one concentration (the size of the read-out at that concentration, not a potency): 27.4%
Estimate against measurement, compound 4: 7.6 percentage points above, and the stated range covers the measured number.
By their numbers in this assay, from the lowest: compounds 4, 2, 1 and 3 (each within the scatter of the next).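

Exchanging the group for 4-(4-fluorophenyl)-1,3-thiazol-2-yl in this assay gives a number 6.6 percentage points lower from compound 2 to compound 4 (within the scatter), a number 6.7 percentage points lower from compound 1 to compound 4 (within the scatter) and a number 7.7 percentage points lower from compound 3 to compound 4 (within the scatter). Going by these compounds alone, these steps are larger than any seen among the earlier compounds, yet all three remain within the scatter, so even this change, which alters both the five-membered ring and the phenyl ring, shows no real difference at this position. Nothing measured on these groups is available to account for the size of these steps.

From the compounds shown here alone, compound 4 changes the five-membered ring and adds fluorine in a single step, so the contribution of each remains unknown. All four compounds carry an aromatic group with a phenyl ring here, which leaves open how the read-out would respond to a piperidine, a carboxylic acid or a longer chain at this position.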